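The compounds below may be only part of what the source reports. "The series", "measured", "known", "first", "only" and "open" are said of these compounds alone.

The measured compounds:

Compound 1 `FC(F)(F)c1ccc(CN2CCN(Cc3cc(-c4ccc(OCc5ccccc5Cl)cc4)on3)CC2)cc1` gives 2800 nM in a functional assay on MCF7 cells (Homo sapiens) for antiproliferative activity, read by sulforhodamine B assay, with a stated time of 72 h; a higher number here means a weaker inhibitor, a lower number a stronger inhibitor.
Compound 2 `FC(F)(F)c1ccc(CN2CCN(Cc3cc(-c4ccc(OCc5cccc(Cl)c5)cc4)on3)CC2)cc1` gives 1400 nM in this assay.
Compound 3 `Fc1ccc(COc2ccc(-c3cc(CN4CCN(Cc5ccc(C(F)(F)F)cc5)CC4)no3)cc2)cc1` gives 7900 nM in this assay.

Among these three numbers compound 1 stands second highest. Its nearest neighbour is compound 2, with a 2.0-fold lower number from compound 1 to compound 2 (0.30 log units; within the scatter), so the two cannot be told apart. Compound 3 lies furthest away, with a 2.8-fold higher number from compound 1 to compound 3 (0.45 log units; beyond the scatter), and from compound 2 the gap is wider still, a 5.6-fold higher number from compound 2 to compound 3 (0.75 log units; beyond the scatter).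

Compound 4 `COc1ccc(COc2ccc(-c3cc(CN4CCN(Cc5ccc(C(F)(F)F)cc5)CC4)no3)cc2)cc1` has not yet been measured in this assay. It differs from compound 1 in one place: 4-methoxyphenyl in place of 2-chlorophenyl on a saturated chain carbon bound to an oxygen on an aromatic ring.

Going by the values given here, the step that bears most on this change is the one from compound 1 to compound 3, where a 4-fluorophenyl group also replaced the 2-chlorophenyl group on the same saturated chain carbon and the number rose modestly. Among the compounds with values here, compound 4 carries a 4-methoxyphenyl group instead, for which no measured step exists, so the direction is taken from compound 3 and the size is kept cautious. Compound 4 is therefore expected to give a number somewhat higher than compound 1, a step of about a 1.8-fold higher number from compound 1 to compound 4 (0.25 log units; within the scatter), with the estimate for compound 4 in this assay being 5000 nM, ranging from 2200 nM to 12000 nM.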

Compound 4, half-maximal inhibitory concentration: 1300 nM
Beside the measured number, compound 4's estimate is 3.8-fold (0.59 log units) above it; measured number below the stated range.
By their numbers in this assay, from the lowest: compounds 4, 2 and 1 (each within the scatter of the next, the first and the last beyond it); then compound 3.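

In this assay the 4-methoxyphenyl group on the saturated chain carbon bound to an oxygen on an aromatic ring moves the number the opposite way from the 4-fluorophenyl group, with a 2.2-fold lower number from compound 1 to compound 4 (0.33 log units; beyond the scatter), so a group in the 4-position of this phenyl ring does not in itself raise the number. Methoxy in place of fluoro on an aromatic carbon gives a 6.1-fold lower number from compound 3 to compound 4 (0.78 log units; beyond the scatter), which ties the high number of compound 3 to the fluoro group and not to substitution at that ring position in general. Against the 3-chlorophenyl group there is a 1.1-fold lower number from compound 2 to compound 4 (0.03 log units; within the scatter), so compound 2 and compound 4 cannot be told apart, and this place accepts two quite different substituted phenyl groups at the same level.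

Nothing available explains why these groups differ as they do. Still open, as far as these compounds go, is whether a 4-chlorophenyl or a 3-methoxyphenyl group would stand with compound 4 or with compound 3, and what an unsubstituted phenyl group, or an ethoxy or longer alkoxy chain in place of methoxy, would give here.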